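The source may report more compounds than this note shows. Statements on the series, on what has been measured and on what is new or still open speak of the compounds shown alone.

Measured so far:
compound 1 `COC(=O)/C=C/c1cccc(N(Cc2ccc(/C=C/c3scnc3C)cc2)C(=O)C(C)C)c1` – 228 nM
compound 2 `COC(=O)/C=C/c1cccc(N(Cc2ccc(-c3ccc(SC)cc3)cc2)C(=O)C(C)C)c1` – 51 nM

In an assay on isolated protein with Bile acid receptor (Homo sapiens) as the target (on this read-out lower numbers stand for an effect already at smaller amounts and higher numbers for an effect only at larger amounts of compound), compound 2 gives the lowest of the two numbers; the nearest is compound 1, whose value sits higher, and the step of a 4.5-fold lower number from compound 1 to compound 2 (0.65 log units; beyond the scatter) lies beyond the scatter.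

Compound 3 `COC(=O)/C=C/c1cccc(N(Cc2ccc(-c3cccc(C)c3)cc2)C(=O)C(C)C)c1` has not been measured. It differs from compound 2 by 3-methylphenyl in place of 4-(methylsulfanyl)phenyl on an aromatic carbon; the change sits on an aromatic carbon of a six-membered aromatic ring of carbon only, para to a large group.

Going by the values given here, only one measured step touches this part of the series, a 4.5-fold lower number from compound 1 to compound 2 (0.65 log units; beyond the scatter), and it swaps the whole ethenyl-linked thiazole for a phenyl bearing methylsulfanyl. Among the compounds with values here, no measured pair separates the contribution of the methylsulfanyl from that of the phenyl itself, so the effect of trading methylsulfanyl for a methyl at a different ring position is not resolved by the data. The expectation for the step from compound 2 to compound 3 is therefore a small change, a 2.0-fold higher number from compound 2 to compound 3 (0.29 log units; within the scatter), most likely toward a somewhat higher number in this assay, within or just beyond the scatter. Compound 3 is thus estimated at 100 nM in this assay, with a range from 35 nM to 300 nM.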

Compound 3, half-maximal effective concentration: 163 nM
Compound 3: the middle estimate sits 1.6-fold (0.21 log units) below what was measured; the measured number falls inside the stated range.
By their numbers in this assay, from the lowest: compound 2; then compounds 3 and 1 (each within the scatter of the next).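

In this assay, the step to 3-methylphenyl gives a 3.2-fold higher number from compound 2 to compound 3 (0.50 log units; beyond the scatter), so the lower number of compound 2 does not carry over to every substituted phenyl at this aromatic carbon; the identity or placement of the substituent on that phenyl matters. Measured against the ethenyl-linked thiazole, the 3-methylphenyl gives a 1.4-fold lower number from compound 1 to compound 3 (0.15 log units; within the scatter), so in this series replacing 2-(4-methyl-1,3-thiazol-5-yl)ethenyl with a methyl-bearing phenyl does not by itself reproduce the step seen with 4-(methylsulfanyl)phenyl. No measurement at hand accounts for the difference between the two phenyl groups.

The step from 4-(methylsulfanyl)phenyl to 3-methylphenyl changes both the substituent and its ring position, so the compounds shown cannot separate these two contributions; 4-methylphenyl and 3-(methylsulfanyl)phenyl would each isolate one of them. Also open, going by these compounds, is how an unsubstituted phenyl or a 4-methoxyphenyl at this carbon would read in this assay, and thus whether the methylsulfanyl is needed for the lower number or another substituent in the same ring position serves equally.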